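Sulfamoyl to methoxy on the anilino ring

A few compounds are considered here, and "the series" means these few. Any claim that something is new, unique, unknown or untested is made for them only; others in the source may bear on it.

Measured so far:
compound 1, `Cc1cc(Nc2cc(N3CCN(C)CC3)nc(Nc3ccc(Cl)cc3)n2)n[nH]1`, 1480 nM
compound 2, `Cc1cc(Nc2cc(N3CCN(C)CC3)nc(Nc3ccc(C#N)cc3)n2)n[nH]1`, 977 nM
compound 3, `Cc1cc(Nc2cc(N3CCN(C)CC3)nc(Nc3ccc(S(N)(=O)=O)cc3)n2)n[nH]1`, 4380 nM

In a functional assay on PC-3 cells (Homo sapiens) for antiproliferative activity, read by CCK-8 assay, with a stated time of 72 h (on this read-out higher numbers stand for weaker inhibition and lower numbers for stronger inhibition), compound 3 stands highest of the three; its nearest neighbour is compound 1, a 3.0-fold higher number from compound 1 to compound 3 (0.47 log units; beyond the scatter), and the furthest is compound 2, a 4.5-fold higher number from compound 2 to compound 3 (0.65 log units; beyond the scatter).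

Compound 4, `COc1ccc(Nc2nc(Nc3cc(C)[nH]n3)cc(N3CCN(C)CC3)n2)cc1`, differs from compound 3 by methoxy in place of sulfamoyl on an aromatic carbon. Going by the values given here, the steps that bear on this are those that leave sulfamoyl behind: a 3.0-fold higher number from compound 1 to compound 3 (0.47 log units; beyond the scatter) and a 4.5-fold higher number from compound 2 to compound 3 (0.65 log units; beyond the scatter), both modest and beyond the scatter. Methoxy has not been tried at this position, so a step back toward the level of compound 1 and compound 2 is expected rather than known, and compound 4 is expected to give a 2.9-fold lower number from compound 3 to compound 4 (0.47 log units; beyond the scatter).

For compound 4 the estimate in this assay is 1500 nM, within 600 nM to 4000 nM.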

Compound 4, half-maximal inhibitory concentration: 2000 nM
Estimate against measurement, compound 4: 1.3-fold (0.12 log units) below, and the stated range covers the measured number.
By their numbers in this assay, from the lowest: compounds 2, 1 and 4 (each within the scatter of the next, the first and the last beyond it); then compound 3.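

In this assay, methoxy recovers part of what sulfamoyl loses, with a 2.2-fold lower number from compound 3 to compound 4 (0.34 log units; beyond the scatter), so compound 3 now stands beyond the scatter of all three other compounds. Methoxy matches chloro, with a 1.4-fold higher number from compound 1 to compound 4 (0.13 log units; within the scatter), but stays short of cyano, with a 2.0-fold higher number from compound 2 to compound 4 (0.31 log units; beyond the scatter). No measurement available here accounts for these differences.

Open, going by these compounds, is whether a carboxylic acid or an amine at this position would fall with compound 3 or with the other three. Also open, on these data alone, is whether a longer alkoxy chain would hold the level of compound 4.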